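The compounds below may be only part of what the source reports. "The series", "measured", "known", "first", "only" and "open" are said of these compounds alone.

Working notes on the series, measured in a functional assay (plasma) for inhibition, with Oryctolagus cuniculus as the target (a lower number here means a stronger inhibitor, a higher number a weaker inhibitor), throughout. Compound 1 (`O=C(O)CCC/C=C\C[C@H]1[C@@H]2CCC(C2)[C@@H]1NS(=O)(=O)c1ccc([N+](=O)[O-])cc1`) gives 1400 nM and compound 2 (`O=C(O)CCC/C=C\C[C@H]1[C@@H]2CCC(C2)[C@@H]1NS(=O)(=O)c1ccc(C(=O)O)cc1`) gives 800000 nM here. Compound 3 (`O=C(O)CCC/C=C\C[C@H]1[C@@H]2CCC(C2)[C@@H]1NS(=O)(=O)CCc1ccccc1`) gives 8200 nM as the middle of the three numbers. Next comes compound 4 (`COc1ccc(S(=O)(=O)N[C@H]2C3CC[C@H](C3)[C@@H]2C/C=C\CCCC(=O)O)cc1`), with 4-methoxyphenyl in place of phenethyl on a sulfonyl sulfur. The closest measured change is the modest step (a 5.9-fold higher number from compound 1 to compound 3 (0.77 log units; beyond the scatter)) in which phenethyl replaces 4-nitrophenyl. Taken in reverse, it points to a lower number when a phenyl-bearing group returns directly to the sulfonyl sulfur. Compound 2 goes against that reading, since its 4-carboxyphenyl group sits at the high end of both large steps (a 570-fold higher number from compound 1 to compound 2 (2.76 log units; beyond the scatter)) and (a 98-fold lower number from compound 2 to compound 3 (1.99 log units; beyond the scatter)). Going by the values given here, no measured compound carries 4-methoxyphenyl, so the direction remains tentative. A modest move to a lower number, not a large one, is therefore expected in this assay for this change. The expected step is a 3.3-fold lower number from compound 3 to compound 4 (0.52 log units; beyond the scatter) on this estimate. For compound 4 the estimated value is 2500 nM within an expected range of 700 nM to 9000 nM overall.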

Compound 4, half-maximal inhibitory concentration: 1700 nM
Compound 4: the middle estimate sits 1.5-fold (0.17 log units) above what was measured; the measured number falls inside the stated range.
By their numbers in this assay, from the lowest: compounds 1 and 4 (each within the scatter of the next); then compound 3; then compound 2.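

In this assay, a substituted phenyl group directly on the sulfonyl sulfur again gives a lower number than phenethyl, a 4.8-fold lower number from compound 3 to compound 4 (0.68 log units; beyond the scatter), so that direction no longer rests on compound 1 alone. Methoxy and nitro on the aromatic carbon cannot be told apart here, a 1.2-fold higher number from compound 1 to compound 4 (0.08 log units; within the scatter), whereas carboxy stands far from methoxy, a 470-fold lower number from compound 2 to compound 4 (2.67 log units; beyond the scatter), which leaves compound 2 as the exception among the directly attached aryl groups. Nothing on hand accounts for these differences.

Going by these compounds, it remains open whether the high number of compound 2 is specific to the carboxylic acid or would also appear with an amide or an amine on the same aromatic carbon. Also open, on these data alone, is whether an unsubstituted phenyl or a chloro group there would match compounds 1 and 4, and whether benzyl on the sulfonyl sulfur would follow phenethyl.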